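Aryl-to-cyclohexyl swap in an isoxazole series

The source may report more compounds than this note shows. Statements on the series, on what has been measured and on what is new or still open speak of the compounds shown alone.

Measured so far:
compound 1, `Fc1cccc(Cl)c1-c1cc(-c2cnn(C3CCNCC3)c2)on1`, 48 nM
compound 2, `Fc1cccc(-c2cc(-c3cnn(C4CCNCC4)c3)on2)c1Cl`, 230 nM

Both numbers come from an assay on isolated protein for positive allosteric modulation of Neuronal acetylcholine receptor; alpha4/beta2 (Homo sapiens); on this read-out higher numbers stand for an effect only at larger amounts of compound and lower numbers for an effect already at smaller amounts. Compound 1 has the lowest of the two numbers; the nearest is compound 2, reached by a 4.8-fold higher number from compound 1 to compound 2 (0.68 log units; beyond the scatter). That single step shows that the group at this position is not indifferent: moving two halogens around the same ring already shifts the read-out beyond the scatter.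

Compound 3, `c1nn(C2CCNCC2)cc1-c1cc(C2CCCCC2)no1`, is not yet measured in this assay. It differs from compound 1 by cyclohexyl in place of 2-chloro-6-fluorophenyl on an aromatic carbon. For the measured compounds named here, no measured pair covers an exchange of an aromatic ring for a non-aromatic one at this position, so there is no direct step to lean on. Going by the values given here, the only step that bears on it is a 4.8-fold higher number from compound 1 to compound 2 (0.68 log units; beyond the scatter), which puts a lower bound on how sensitive this position is. A larger change at the same place is therefore expected to give at least a step of similar size, most likely upward. For compound 3 the expected step is a 7.3-fold higher number from compound 1 to compound 3 (0.86 log units; beyond the scatter), giving an estimate of 350 nM with a range from 70 nM to 1800 nM.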

Compound 3, half-maximal effective concentration: 4600 nM
Beside the measured number, compound 3's estimate is 13-fold (1.12 log units) below it; the measured number lies above the stated range.
By their numbers in this assay, from the lowest: compound 1; then compound 2; then compound 3.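

In this assay, replacing the halogenated aromatic ring with cyclohexyl matters far more than rearranging the halogens on that ring: a 96-fold higher number from compound 1 to compound 3 (1.98 log units; beyond the scatter) and a 20-fold higher number from compound 2 to compound 3 (1.30 log units; beyond the scatter), whereas the halogen shift gave only a 4.8-fold higher number from compound 1 to compound 2 (0.68 log units; beyond the scatter). Compound 3 therefore stands well apart from both halogenated compounds, whichever of the two is taken as the reference, and at this place on the five-membered ring a six-membered carbon ring is not interchangeable with its aromatic counterpart. The exchange removes the aromatic ring, the chlorine and the fluorine in one step, and nothing available accounts for the size of this loss.

The compounds shown do not separate the contribution of the halogens from that of the aromatic ring, and a plain phenyl group at this place would sit directly between those two questions. A pyridyl ring or a fluorinated cyclohexyl would further test whether the ring itself or its halogens carry the difference.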